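Tert-butyl in place of phenyl on compound 2

The source may report more compounds than this note shows. Statements on the series, on what has been measured and on what is new or still open speak of the compounds shown alone.

Of the compounds shown here, two have so far been measured in a physicochemical assay for lipophilicity, using potentiometric titration, at pH 7.4; a lower number here means a more polar compound, a higher number a more lipophilic compound. Compound 1 (`Fc1ccc(-c2nc(-c3ccc4nc[nH]c4c3)no2)cc1`) gives 3.37 and compound 2 (`Fc1ccc(-c2nc(-c3ccc(-c4ccccc4)cc3)no2)cc1F`) gives 4.75 as the higher of the two numbers, a gap beyond the scatter. Compound 3 (`CC(C)(C)c1ccc(-c2noc(-c3ccc(F)c(F)c3)n2)cc1`) has not yet been measured. It differs from compound 2 in one place, and the difference is tert-butyl in place of phenyl on an aromatic carbon in which tert-butyl stands in place of phenyl on an aromatic carbon, para to a large group. Among the compounds with values here, no measured pair shows this change, so the expectation rests on the structures alone. Both groups are made of carbon only and carry no net charge. The estimated step is a number 0.05 log units lower from compound 2 to compound 3 (within the scatter) in this assay and is expected to stay within the scatter, with no clear direction. For compound 3 the estimated value is 4.7 with an expected range from 4.3 to 5.1 in this measurement.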

Compound 3, distribution coefficient: 3.92
Compound 3: the middle estimate sits 0.78 log units above what was measured; the whole stated range lies above it.
By their numbers in this assay, from the lowest: compound 1; then compound 3; then compound 2.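

Tert-butyl in place of phenyl on an aromatic carbon is the first single change that can be read in this assay, and it gives a number 0.83 log units lower from compound 2 to compound 3 (beyond the scatter). The read-out at this place, para to a large group, therefore depends on which of these two groups stands there, even though both are made of carbon only, carry no net charge and have no hydrogen-bond donors or acceptors. Nothing measured on these compounds accounts for the size of the step.

One pair cannot separate the loss of the aromatic ring from the change in the number of carbons, and a cyclohexyl ring at this place would bear on that question. As far as these compounds go, how an amine or a carboxylic acid would behave here, and whether the same change gives a similar step on the core of compound 1, also remains open.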